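From Benzyloxycarbonyl to 4-Methoxyphenyl on the Shared Core

This account rests on a few compounds, and the source may have more. Where it says the series, first, only, none or still open, it means among the compounds named here.

The two compounds measured so far, with their values in a functional assay on WI-38 VA13 cells (Homo sapiens) for cytotoxicity; a lower number here means that less compound is needed, a higher number that more compound is needed for the effect:
compound 1 `O=C(Nc1ccc2nc(NC(=O)C3CC3)sc2c1)c1c(Cl)cccc1Cl` gives 0.013 ug/mL;
compound 2 `O=C(Nc1nc2ccc(NC(=O)c3c(Cl)cccc3Cl)cc2s1)OCc1ccccc1` gives 0.018 ug/mL.

Among the compounds with values here, compound 2 has the highest of these two numbers, but the only step connecting them, a 1.4-fold higher number from compound 1 to compound 2 (0.14 log units; within the scatter), lies within the scatter, so the two cannot be told apart. Compound 3 `COc1ccc(Nc2nc3ccc(NC(=O)c4c(Cl)cccc4Cl)cc3s2)cc1` has not yet been measured. It differs from compound 2 in one place: 4-methoxyphenyl in place of benzyloxycarbonyl on a nitrogen on an aromatic ring. Within the data shown here, the one measured step bears on the same nitrogen, where a cyclopropyl and a benzyloxy on a carbonyl carbon gave the same result; it does not speak directly to replacing the whole benzyloxycarbonyl with a 4-methoxyphenyl, so no firm direction can be drawn from it. The expected step is therefore modest: a 1.7-fold higher number from compound 2 to compound 3 (0.22 log units; within the scatter). In this assay compound 3 is estimated at 0.03 ug/mL, ranging from 0.008 ug/mL to 0.12 ug/mL.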

Compound 3, half-maximal effective concentration: 0.87 ug/mL
Compound 3: the middle estimate sits 29-fold (1.46 log units) below what was measured; the whole stated range lies below it.
By their numbers in this assay, from the lowest: compounds 1 and 2 (each within the scatter of the next); then compound 3.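

The nitrogen on the aromatic ring turns out to be sensitive to what it carries in this assay. Replacing the benzyloxycarbonyl with 4-methoxyphenyl gives a 48-fold higher number from compound 2 to compound 3 (1.68 log units; beyond the scatter), and replacing the cyclopropylcarbonyl with the same group gives a 67-fold higher number from compound 1 to compound 3 (1.83 log units; beyond the scatter), so both carbonyl-linked groups part sharply from the aryl group, although the earlier pair could not be told apart. No measurement here explains this shift.

Each step removes the carbonyl on this nitrogen and brings in the 4-methoxyphenyl at once, so the compounds shown leave open which of the two changes matters. A plain phenyl without the methoxy, or a simple amine at this nitrogen, would help separate those two readings.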